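Putting 1H-pyrrol-3-yl in place of 1H-imidazol-4-yl

The source may report more compounds than this note shows. Statements on the series, on what has been measured and on what is new or still open speak of the compounds shown alone.

In a functional assay on A549 cells (Homo sapiens), read by sulforhodamine B assay, with a stated time of 5 days (a higher number here means a weaker inhibitor of growth, a lower number a stronger inhibitor of growth), compound 1 `OC[C@H]1O[C@@H](n2cc(F)c3c(-c4ccc[nH]4)ncnc32)[C@H](O)[C@@H]1O` gives 190 nM. Compound 2 `OC[C@H]1O[C@@H](n2cc(F)c3c(-c4c[nH]cn4)ncnc32)[C@H](O)[C@@H]1O` gives > 10000 nM, which is a limit of the assay and not a number. Compound 3 `OC[C@H]1O[C@@H](n2cc(F)c3c(-c4cc[nH]c4)ncnc32)[C@H](O)[C@@H]1O` carries 1H-pyrrol-3-yl in place of 1H-imidazol-4-yl on an aromatic carbon. Going by the values given here, the one measured step bearing on this change is an at least 52-fold higher number from compound 1 to compound 2 (1.72 log units; beyond the scatter), a large step beyond the scatter that put 1H-imidazol-4-yl in place of 1H-pyrrol-2-yl. On that step a large move to a lower number is expected, although 1H-pyrrol-3-yl is not the group of compound 1. Compound 3 is expected at 500 nM, with an estimated range of 100 nM to 4000 nM. The expected step is an at least 20-fold lower number from compound 2 to compound 3 (1.30 log units; beyond the scatter).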

Compound 3, concentration for 50% growth inhibition: 130 nM
Estimate against measurement, compound 3: 3.8-fold (0.59 log units) above, and the stated range covers the measured number.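

On this aromatic carbon, this assay does not tell 1H-pyrrol-3-yl from 1H-pyrrol-2-yl, with a 1.5-fold lower number from compound 1 to compound 3 (0.16 log units; within the scatter). The large loss therefore belongs to 1H-imidazol-4-yl among these three groups and does not depend on one pyrrole attachment, with an at least 76-fold lower number from compound 2 to compound 3 (1.88 log units; beyond the scatter). Compound 2 stands at a limit of the assay and not at a number: the limit of > 10000 nM in this assay, at which 1 of the 3 values shown sits.

As far as these compounds go, the true size of that step remains open. So does what a phenyl ring, a furan ring or an amine would give on this carbon.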